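The source may report more compounds than this note shows. Statements on the series, on what has been measured and on what is new or still open speak of the compounds shown alone.

Measured in a functional assay on HaCaT cells (Homo sapiens) for antiproliferative activity, read by sulforhodamine B assay, with a stated time of 3 days; on this read-out higher numbers stand for weaker inhibition and lower numbers for stronger inhibition:

Compound 1 `COC(=O)c1cc(CCc2ccc(OC)cc2OC)ccc1O`: 19000 nM
Compound 2 `COC(=O)c1cc(CCc2cc(OC(C)=O)ccc2OC(C)=O)ccc1O`: 24000 nM
Compound 3 `COC(=O)c1cc(CCc2cc(OC)ccc2Br)ccc1O`: 210 nM

Compound 3 has the lowest number of these three, so it is the strongest inhibitor among them. Compound 1 and compound 2 both lie above it by far more than the usual scatter of repeated measurements.

The next compound to consider is compound 4 `CCc1ccc(OC)cc1CCc1ccc(O)c(C(=O)OC)c1`. It keeps everything in compound 3 except for one swap: ethyl in place of bromo on an aromatic carbon, ortho to a large group and para to a methoxy group (ethyl in place of bromo on an aromatic carbon).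

For the measured compounds named here, no two measured compounds differ in only one place, so the data offer no direct precedent for this swap. Going by the values given here, compound 3, at 210 nM, is the only measured compound that carries bromo. It also differs from the other two elsewhere, so its low number cannot be tied to bromo alone. The swap itself is small, which argues against a collapse to the level of compound 1, at 19000 nM, although some loss seems likely.

A moderate step toward weaker inhibition is therefore expected in this assay, estimated as a 2.9-fold higher number from compound 3 to compound 4 (0.46 log units; beyond the scatter). For compound 4 the estimated value is 600 nM, with an expected range of 150 nM to 4000 nM.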

Compound 4, half-maximal inhibitory concentration: 130 nM
Compound 4: middle estimate off by 4.6-fold (0.66 log units), on the high side; the measured number lies below the stated range.
By their numbers in this assay, from the lowest: compounds 4 and 3 (each within the scatter of the next); then compounds 1 and 2 (each within the scatter of the next).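

In this assay, putting ethyl in place of bromo on an aromatic carbon, ortho to a large group and para to a methoxy group, gives a 1.6-fold lower number from compound 3 to compound 4 (0.21 log units; within the scatter) and so leaves the two compounds indistinguishable. For the compounds shown here, this is the first pair here that differs in only one place, which allows this position to be read directly: bromo, with 1 heavy atom, and ethyl, with 2 heavy atoms, fit equally well as far as this read-out can tell, and bromine itself is not needed to keep the number where compound 3 has it. No independent measurement on these compounds is available to explain why the two groups behave alike.

On these data alone, it remains open whether this position would accept something quite different, such as an amine, a carboxylic acid or a longer chain like butyl, or whether the range of groups it accepts is limited to small ones like these two. Compound 1 and compound 2 each differ from compound 3 in more than one place, so which of those differences accounts for their much higher numbers also remains unresolved.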